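Urea and thiourea analogues: cell-growth inhibition notes

This account rests on a few compounds, and the source may have more. Where it says the series, first, only, none or still open, it means among the compounds named here.

Measured so far in a functional assay on T98G cells (Homo sapiens) for inhibition, read by MTT assay, with a stated time of 72 h; a lower number here means a stronger inhibitor, a higher number a weaker inhibitor:
compound 1, `CC1(C)CC(NC(=O)NCc2ccccc2)c2cc(Cl)ccc2O1`, 15000 nM
compound 2, `CC1(C)CC(NC(=S)NCc2ccccc2)c2cc(Br)ccc2O1`, 54000 nM
compound 3, `CC1(C)CC(NC(=O)Nc2ccc(Cl)cc2)c2cc(Cl)ccc2O1`, 33000 nM

Compound 1 and compound 3 share a core and differ by 4-chlorophenyl in place of benzyl on an amide-type nitrogen. That change gave a 2.2-fold higher number from compound 1 to compound 3 (0.34 log units; beyond the scatter). Compound 2 stands on another core; the difference between the core of compound 1 and the core of compound 2 is not broken down here. Compound 2 and compound 3 lie within the usual scatter of each other, so no order is read between them. Compound 2 does give a higher number than compound 1, beyond the scatter.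

Compound 4, `CC1(C)CC(NC(=S)Nc2ccc(Cl)cc2)c2cc(Br)ccc2O1`, is not yet measured. It differs from compound 2 by 4-chlorophenyl in place of benzyl on an amide-type nitrogen. The surroundings of the place are not the same: in compound 1 and compound 3 the other neighbour of that nitrogen is a carbonyl carbon, in compound 2 and compound 4 a thiocarbonyl carbon, so this is the same kind of change, not the same change.

The expected step is a 2.0-fold higher number from compound 2 to compound 4 (0.31 log units; beyond the scatter) in this assay. This rests on a 2.2-fold higher number from compound 1 to compound 3 (0.34 log units; beyond the scatter) and on compound 2 at 54000 nM. For compound 4 the estimate is 110000 nM. For compound 4 the expected range runs from 45000 nM to 260000 nM.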

Compound 4, half-maximal inhibitory concentration: 22000 nM
For compound 4 the middle estimate is 5.0-fold (0.70 log units) above the measured one, and the stated range ends above it.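

In this assay, 4-chlorophenyl in place of benzyl on the amide-type nitrogen gives a 2.5-fold lower number from compound 2 to compound 4 (0.39 log units; beyond the scatter), so the same change runs in opposite directions on the two cores: the same change on two cores in this assay, a 2.2-fold higher number (0.34 log units; beyond the scatter) from compound 1 to compound 3 and a 2.5-fold lower number (0.39 log units; beyond the scatter) from compound 2 to compound 4, 5.4-fold (0.73 log units) apart, beyond the scatter of two such steps
In this series, the direction of this step therefore does not carry over from the core of compound 1 to the core of compound 2, and a step read on one of these cores is a poor guide to the other. What this does not show is which difference in the cores goes with the reversal, since the carbonyl carbon gives way to a thiocarbonyl carbon and chlorine gives way to bromine together, and with one pair per core no rule for other cores follows.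

The compounds shown leave open how the change behaves when only the carbonyl or only the halogen differs. They also leave open what a phenethyl chain, or a carboxylic acid on the phenyl ring, would do at the same nitrogen.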